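The compounds below may be only part of what the source reports. "The series", "measured", "known", "first", "only" and "open" are said of these compounds alone.

In an assay on membranes from brain with Neuronal acetylcholine receptor; alpha4/beta2 (Rattus norvegicus) as the target (on this read-out higher numbers stand for weaker inhibition and lower numbers for stronger inhibition), three compounds have been measured:

Compound 1 `Fc1ncc(OC[C@@H]2CCN2)cc1-c1cccnc1` gives 0.066 nM.
Compound 2 `Brc1ncc(OC[C@@H]2CCN2)cc1-c1cccnc1` gives 0.0066 nM.
Compound 3 `Fc1cc(/C=C/c2cc(OC[C@@H]3CCCN3)cnc2Cl)ccn1` gives 0.0094 nM.

Compound 1 and compound 2 differ in one place only: bromo in place of fluoro on an aromatic carbon. This change gave a 10-fold lower number from compound 1 to compound 2 (1.00 log units; beyond the scatter). Compound 3 has a different core from compound 1, and the difference between the two cores is not broken down here. Compound 4 `Clc1ncc(OC[C@@H]2CCCN2)cc1/C=C/c1ccnc(Br)c1` is not yet measured; it differs from compound 3 in one place: bromo in place of fluoro on an aromatic carbon. The same change, bromo in place of fluoro on an aromatic carbon, thus occurs twice among these four compounds. It is the same kind of change, not the same one, since the surroundings differ: in compound 1 the carbon is ortho to a pyridin-3-yl group and para to a (azetidin-2-yl)methoxy group, whereas in compound 3 it is meta to a large group. Because the earlier step of a 10-fold lower number from compound 1 to compound 2 (1.00 log units; beyond the scatter) ran toward stronger inhibition, a step of similar direction but possibly smaller size, a 3.1-fold lower number from compound 3 to compound 4 (0.50 log units; beyond the scatter), is expected here. Compound 4 is therefore estimated at 0.003 nM, between 0.0008 nM and 0.012 nM.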

Compound 4, inhibition constant: 0.0056 nM
Compound 4: middle estimate off by 1.9-fold (0.27 log units), on the low side; the range from low to high includes it.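

In this assay, replacing the 2-fluoropyridin-4-yl group with a 2-bromopyridin-4-yl group gave a 1.7-fold lower number from compound 3 to compound 4 (0.22 log units; within the scatter), so on this core the two halogens cannot be told apart by this read-out. Going by these compounds alone, the size of the step did not carry over from one core to the other, even though the swap of atoms is the same: the same change on two cores in this assay, a 10-fold lower number (1.00 log units; beyond the scatter) from compound 1 to compound 2 and a 1.7-fold lower number (0.22 log units; within the scatter) from compound 3 to compound 4, 6.0-fold (0.78 log units) apart, beyond the scatter of two such steps This shows that the large step seen on the core of compound 1 is no safe guide to the step on the core of compound 3, but with only two pairs it does not show which structural difference between the cores matters, or why the steps differ.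

The compounds shown leave open how a methyl group or an amine would compare with fluoro and bromo at this place on either core. They also leave open whether the same swap on a further core would give a step closer to the large one or to the small one.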